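This account rests on a few compounds, and the source may have more. Where it says the series, first, only, none or still open, it means among the compounds named here.

Compound 1 `CCOC(=O)c1cc(NC(=O)NC(=O)c2c(Cl)cccc2Cl)ccc1Oc1cncc(Cl)c1` and compound 2 `Cc1c(Cc2c(Cl)cccc2Cl)c(=O)oc2cc(OCC(=O)OCC(=O)c3ccc(Cl)cc3)ccc12` have been run in a functional assay (Homo sapiens) for inhibition, tested at 0.1 uM; a lower number here means a weaker effect, a higher number a stronger effect of the compound at the concentration tested. Compound 1 gives 90%, while compound 2 gives 72%, the lower of the two numbers; the gap to compound 1 lies beyond the usual scatter. Compound 3 `Cc1c(Cc2c(Cl)cccc2Cl)c(=O)oc2cc(OCC(=O)OCC(=O)c3ccccc3)ccc12` differs from compound 2 by hydrogen in place of chloro on an aromatic carbon. Among the measured compounds shown here, no measured pair isolates this change. The step of a number 7 percentage points lower from compound 2 to compound 3 (within the scatter) is estimated to be small, within the scatter or slightly downward. In this assay compound 3 is therefore expected to give 65%, with a range from 45% to 82%.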

Compound 3, a percentage reported as inhibition, at one concentration (the size of the read-out at that concentration, not a potency): 49%
Compound 3: middle estimate off by 16 percentage points, on the high side; low and high end bracket the measured number.
By their numbers in this assay, from the lowest: compound 3; then compound 2; then compound 1.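

The 4-chlorophenyl to phenyl change gives the series its first comparison at a single place: in this assay, hydrogen in place of chloro gives a number 23 percentage points lower from compound 2 to compound 3 (beyond the scatter). The chloro at this position, para to a large group, therefore contributes to the read-out at the concentration tested, and the change is larger than the scatter. Nothing available bears on the reason for this difference.

From the compounds shown here alone, whether a fluoro, methoxy or amine at the same carbon would hold the level of compound 2 remains open. A read-out at one concentration also shows only the size of the effect of compound 2 and compound 3 at that concentration.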